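Trimming the nitrogen substituent from benzyl to ethyl

This account rests on a few compounds, and the source may have more. Where it says the series, first, only, none or still open, it means among the compounds named here.

In a functional assay on MCF7 cells (Homo sapiens) for cytotoxicity, read by MTT assay, with a stated time of 24 h (a lower number here means a stronger inhibitor, a higher number a weaker inhibitor), compound 1 `CCOC(=O)c1cn(CCCc2ccccc2)c2cc(Cl)ccc2c1=O` gives 14100 nM and compound 3 `CCOC(=O)c1cn(Cc2ccccc2)c2cc(Cl)ccc2c1=O` gives 15800 nM. Compound 2 `CCCCn1cc(C(=O)OCC)c(=O)c2ccc(Cl)cc21` reaches only the limit > 50000 nM. Among the two numbers, compound 3 has the highest, with compound 1 nearest: a 1.1-fold higher number from compound 1 to compound 3 (0.05 log units; within the scatter). Compound 4 `CCOC(=O)c1cn(CC)c2cc(Cl)ccc2c1=O` differs from compound 3 by methyl in place of phenyl on a saturated chain carbon bound to an aromatic nitrogen. Among the compounds with values here, two measured steps bear on this change: an at least 3.5-fold higher number from compound 1 to compound 2 (0.54 log units; beyond the scatter) and an at least 3.1-fold lower number from compound 2 to compound 3 (0.50 log units; beyond the scatter), both pointing the same way, toward a higher number once the phenyl is gone, and both involving (the limit of > 50000 nM in this assay, at which 1 of the 3 values shown sits). Compound 4 is therefore expected to show a 3.5-fold higher number from compound 3 to compound 4 (0.54 log units; beyond the scatter) in this assay. Compound 4 is estimated at 55000 nM, within a range from 20000 nM to 150000 nM, with a real chance that only a limit is reported.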

Compound 4, half-maximal inhibitory concentration: > 50000 nM
Compound 4 gave a limit, no number; the forecaster's own chance of this, stated with the estimate: 55%; the middle value does not contradict the limit.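

In this assay, methyl in place of phenyl on the saturated chain carbon bound to the aromatic nitrogen gives an at least 3.1-fold higher number from compound 3 to compound 4 (0.50 log units; beyond the scatter), and the ethyl group of compound 4 also compares with the longer chain through an at least 3.5-fold higher number from compound 1 to compound 4 (0.54 log units; beyond the scatter). The loss of the phenyl thus appears at a second place on the chain: the same change on two cores in this assay, an at least 3.5-fold higher number (0.54 log units; beyond the scatter) from compound 1 to compound 2 and an at least 3.1-fold higher number (0.50 log units; beyond the scatter) from compound 3 to compound 4; the limit leaves it open whether they differ. Compound 2 and compound 4 both stand at a limit, and the step between them cannot be read: the limit of > 50000 nM in this assay, at which 2 of the 4 values shown sit.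

From the compounds shown here alone, the true size of these steps stays open. So does whether an amine or a carboxylic acid on the chain could replace the phenyl and keep the number of compound 3.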